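Benzyl exchange in a series sitting at its limit

A few compounds are considered here, and "the series" means these few. Any claim that something is new, unique, unknown or untested is made for them only; others in the source may bear on it.

In an in vitro ADME assay on microsomes from liver (Homo sapiens) for metabolic stability, tested at 1 uM (a lower number here means that the compound disappears faster, a higher number that the compound lasts longer), compound 1 `CS(=O)(=O)Nc1ccc2c(c1)S(=O)(=O)N=C(C1=C(O)[C@@H]3[C@@H]4CC[C@@H](C4)[C@@H]3N(Cc3ccccc3F)C1=O)N2` gives > 1 h, which is a limit and not a number. Compound 2 `COc1cccc(CN2C(=O)C(C3=NS(=O)(=O)c4cc(NS(C)(=O)=O)ccc4N3)=C(O)[C@@H]3[C@@H]4CC[C@@H](C4)[C@@H]32)c1` gives > 1 h, which is also a limit and not a number. For the measured compounds named here, the series so far shows only (the limit of > 1 h in this assay, at which 2 of the 2 values shown sit), so compound 2 has no readable position.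

Compound 3 `CS(=O)(=O)Nc1ccc2c(c1)S(=O)(=O)N=C(C1=C(O)[C@@H]3[C@@H]4CC[C@@H](C4)[C@@H]3N(Cc3ccc(F)c(Cl)c3)C1=O)N2` differs from compound 2 by one change, 3-chloro-4-fluorophenyl in place of 3-methoxyphenyl on a saturated chain carbon bound to an amide-type nitrogen in a ring: 3-chloro-4-fluorophenyl in place of 3-methoxyphenyl, on a saturated chain carbon bound to an amide-type nitrogen in a ring. Going by the values given here, the one measured step at that place is a step that the two limits leave unreadable from compound 1 to compound 2. It gives no size to carry forward, so neither a step beyond the scatter nor a direction is expected in this assay. Compound 3 is expected to be reported as a limit again. The expected step is a step that the limit leaves unreadable from compound 2 to compound 3, a working figure only. For compound 3 the estimated half-life is 2 h, with an expected range from 1 h to 5 h.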

Compound 3, half-life: > 1 h
Compound 3 gave a limit, no number; the forecaster's own chance of this, stated with the estimate: 75%; the middle value is on the limit's open side.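

Compound 3 gives > 1 h, which is a limit and not a number. No step among compound 1, compound 2 and compound 3 can be read in this assay: the limit of > 1 h in this assay, at which 3 of the 3 values shown sit.

The compounds shown leave open how long each of the three actually lasts in this assay, and whether exchanging the benzyl group shifts the half-life at all.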